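A phenoxymethyl ester variant of compound 3

The source may hold more compounds than are shown below. What is called first, only, known or untested is meant among the compounds shown, and "the series" means these compounds.

Compound 3 `CCCc1nc(CC)c(C(=O)OCCC[S+]([O-])c2ccccc2)n1Cc1ccc(-c2ccccc2S(=O)(=O)NC(=O)OCCC(C)C)cc1F` gives 1 nM in an assay on isolated protein for binding affinity to Type-2 angiotensin II receptor (Homo sapiens) (a lower number here means a stronger inhibitor, a higher number a weaker inhibitor), level with compound 1 `CCCc1nc(CC)c(C(=O)OCc2ccccc2OC)n1Cc1ccc(-c2ccccc2S(=O)(=O)NC(=O)OCCC(C)C)cc1F`, which gives 1 nM, the two together being the lowest of the three numbers, while compound 2 `CCCc1nc(CC)c(C(=O)OCc2ccccc2OCCC(C)C)n1Cc1ccc(-c2ccccc2S(=O)(=O)NC(=O)OCCC(C)C)cc1F` gives 10 nM. Compound 4 `CCCc1nc(CC)c(C(=O)OCCCCOc2ccccc2)n1Cc1ccc(-c2ccccc2S(=O)(=O)NC(=O)OCCC(C)C)cc1F` differs from compound 3 by a group of 8 heavy atoms (7 carbon, 1 oxygen; one six-membered aromatic ring of carbon only) in place of a group of 8 heavy atoms (6 carbon, 1 oxygen, 1 sulfur; one six-membered aromatic ring of carbon only), on a saturated chain carbon, three bonds along the chain from an oxygen next to a carbonyl group. The measured steps at the ester side chain bear on this: no change at the digits printed from compound 1 to compound 3 (within the scatter), a 10-fold lower number from compound 2 to compound 3 (1.00 log units; beyond the scatter), and a 10-fold higher number from compound 1 to compound 2 (1.00 log units; beyond the scatter). Within the data shown here, only the step that adds isobutyl moved the number; exchanging one ring-bearing group for another of similar size did not. Compound 4 keeps a ring-bearing group of the same size, so the expected step is a 1.5-fold higher number from compound 3 to compound 4 (0.18 log units; within the scatter), within the scatter. For compound 4 the estimate in this assay is 1.5 nM, with a range from 0.5 nM to 5 nM.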

Compound 4, half-maximal inhibitory concentration: 2 nM
Compound 4: the middle estimate sits 1.3-fold (0.12 log units) below what was measured, and the stated range covers the measured number.
By their numbers in this assay, from the lowest: compounds 1, 3 and 4 (each within the scatter of the next); then compound 2.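

In this assay, phenoxymethyl in place of the sulfur-bearing group gives a 2.0-fold higher number from compound 3 to compound 4 (0.30 log units; within the scatter) and so leaves the number within the scatter. With 3-phenoxypropyl in place of 2-(isopentyloxy)phenyl the result is a 5.0-fold lower number from compound 2 to compound 4 (0.70 log units; beyond the scatter) and with 3-phenoxypropyl in place of 2-methoxyphenyl it is a 2.0-fold higher number from compound 1 to compound 4 (0.30 log units; within the scatter) so among these four compounds only compound 2 stands apart. Nothing available accounts for these numbers.

The compounds shown leave open how an amine or a carboxylic acid on this side chain would read, and whether a longer chain would keep compound 4's number.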